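Amine substituent and metabolic stability in the series

The compounds below may be only part of what the source reports. "The series", "measured", "known", "first", "only" and "open" are said of these compounds alone.

compound 1 `CCCN(C[C@H]1Cc2c(cccc2N2CCNCC2)CN1)[C@H]1CCCc2cccnc21`: 100%
compound 2 `c1cnc2c(c1)CCC[C@@H]2N(CC1CCCCC1)C[C@H]1Cc2c(cccc2N2CCNCC2)CN1`: 81.6%
compound 3 `CN(C[C@H]1Cc2c(cccc2N2CCNCC2)CN1)[C@H]1CCCc2cccnc21`: 99.7%

In an ADME assay on microsomes from liver (Homo sapiens) for metabolic stability, read by LC-MS, with a stated time of 10 min (a higher number here means that more of the compound is left, a lower number that less of the compound is left), compound 3 stands second highest of the three numbers. Its nearest neighbour is compound 1, the step of a number 0.3 percentage points lower from compound 1 to compound 3 (within the scatter) being within the scatter, and compound 2 lies furthest off, with a number 18.1 percentage points higher from compound 2 to compound 3 (beyond the scatter) beyond the scatter.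

Compound 4 `FC1(F)CCC(CN(C[C@H]2Cc3c(cccc3N3CCNCC3)CN2)[C@H]2CCCc3cccnc32)CC1` differs from compound 3 as follows: 4,4-difluorocyclohexyl in place of hydrogen on a saturated chain carbon bound to an amine nitrogen. Going by the values given here, two measured steps bear on this change, both placing a saturated ring on that same carbon: a number 18.4 percentage points lower from compound 1 to compound 2 (beyond the scatter) and, in reverse, a number 18.1 percentage points higher from compound 2 to compound 3 (beyond the scatter), each a modest step beyond the scatter. A modest fall is therefore expected, a number 17.7 percentage points lower from compound 3 to compound 4 (beyond the scatter). Compound 4 is estimated at 82%, in a range from 65% to 97%.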

Compound 4, percent of the compound remaining: 68.6%
Estimate against measurement, compound 4: 13.4 percentage points above; low and high end bracket the measured number.
By their numbers in this assay, from the lowest: compound 4; then compound 2; then compounds 3 and 1 (each within the scatter of the next).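

Going by these compounds alone, at the saturated chain carbon bound to an amine nitrogen, 4,4-difluorocyclohexyl brings the lowest number so far in this assay, with a number 31.1 percentage points lower from compound 3 to compound 4 (beyond the scatter) and a number 31.4 percentage points lower from compound 1 to compound 4 (beyond the scatter) as the large steps. Fluorine on the ring does not bring the number back towards compound 3, since the pair with the plain ring gives a number 13 percentage points lower from compound 2 to compound 4 (beyond the scatter) and so sits lower still. Nothing at hand explains this fall. Open, from the compounds shown here alone, is whether a hydroxyl or an amine on the cyclohexyl ring would hold the number nearer compound 3. Also open, going by these compounds, is how a longer open chain on that carbon compares with the rings.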